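Swapping a fluorophenyl sulfide for a dichlorophenyl sulfide

The source may report more compounds than this note shows. Statements on the series, on what has been measured and on what is new or still open speak of the compounds shown alone.

Compound 1 `CCOC(=O)[C@H](CCC(=O)O)NC(=O)c1ccc(Sc2nc3cc(N)cc(N)c3nc2-c2ccccc2)cc1`: in a functional assay on NCI-H226 cells (Homo sapiens) for inhibition, read by sulforhodamine B assay, with a stated time of 48 h (on this read-out higher numbers stand for lower toxicity in this test and lower numbers for higher toxicity in this test), compound 1 gives < 100000 nM, which is a limit of the assay rather than a number.
Compound 2 `Nc1cc(N)c2nc(-c3ccccc3)c(Sc3ccc(F)cc3)nc2c1`: in this assay compound 2 gives < 100000 nM, again a limit of the assay and not a number.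

Compound 2 therefore stands at the limit of < 100000 nM in this assay, at which 2 of the 2 values shown sit; nothing more exact is known about it, and compound 1 sits at the same limit. Compound 3 `Nc1cc(N)c2nc(-c3ccccc3)c(Sc3ccc(Cl)c(Cl)c3)nc2c1` has not yet been measured. It differs from compound 2 by 3,4-dichlorophenyl in place of 4-fluorophenyl on a sulfur. For the measured compounds named here, because both known values are limits, no measured step exists to lean on, so in this assay the step from compound 2 to compound 3 is expected to be none beyond the usual scatter, in the sense of the expected step that the limit leaves unreadable from compound 2 to compound 3. On that basis compound 3 is estimated at 20000 nM, with a range from 3000 nM to 100000 nM, and a fair chance that only a limit is reported.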

Compound 3, concentration lethal to 50% of the cells: < 100000 nM
Compound 3: a limit, no number; the forecaster's own chance of this, stated with the estimate: 60%; the middle value lies beyond the limit too.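

No step can be read from compound 2 to compound 3, because both sit at the same limit and neither gives a number: the limit of < 100000 nM in this assay, at which 3 of the 3 values shown sit.

The compounds shown leave open whether 3,4-dichlorophenyl in place of 4-fluorophenyl on a sulfur changes the read-out at all, and in which direction.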